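This account rests on a few compounds, and the source may have more. Where it says the series, first, only, none or still open, it means among the compounds named here.

Three compounds already have numbers in an ADME assay on cells (T-cell, Mus musculus, strain BALB/c) for cytotoxicity, read by MTT assay, with a stated time of 48 h; a higher number here means that more compound is tolerated, a lower number that less compound is tolerated. Compound 1 `C=C(CCc1cc(O)c2c(=O)cc(-c3ccccc3)oc2c1)Cc1c(Br)cccc1C(=O)CC` gives 379000 nM. Compound 2 `COC(=O)c1cccc(OC)c1OC(=O)COc1cc(O)c2c(=O)cc(-c3ccccc3)oc2c1` gives 196000 nM. Compound 3 `COC(=O)c1cccc(C)c1OC(=O)COc1cc(O)c2c(=O)cc(-c3ccccc3)oc2c1` gives 299000 nM. Of these three numbers compound 3 has the second highest; its nearest neighbour is compound 1 and its furthest is compound 2, and both gaps lie within the usual scatter of repeated measurements, so no order among the three can be claimed. Within the data shown here, the single change with a measured compound at both ends is a 1.5-fold higher number from compound 2 to compound 3 (0.18 log units; within the scatter), which also stays within the scatter.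

Compound 4 `COC(=O)c1cc(C)ccc1OC(=O)COc1cc(O)c2c(=O)cc(-c3ccccc3)oc2c1` has not yet been measured. It differs from compound 3 in one place: a group of 11 heavy atoms (9 carbon, 2 oxygen; one six-membered aromatic ring of carbon only) in place of a group of 11 heavy atoms (9 carbon, 2 oxygen; one six-membered aromatic ring of carbon only), on an oxygen next to a carbonyl group. The two groups are built from the same atoms joined differently, so the change is a rearrangement of the same pieces rather than an addition or a loss. Among the measured compounds shown here, the only step that bears on it, a 1.5-fold higher number from compound 2 to compound 3 (0.18 log units; within the scatter), also altered this aromatic ring and moved the number by less than the scatter. No step beyond the scatter is therefore expected in this assay for compound 4. The expected step is a 1.0-fold higher number from compound 3 to compound 4 (0.00 log units; within the scatter). Compound 4 is estimated to give about 300000 nM, within a range from 150000 nM to 600000 nM.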

Compound 4, half-maximal cytotoxic concentration: 306000 nM
The estimate for compound 4 lay 1.0-fold (0.01 log units) below the measured number; the measured number falls inside the stated range.
By their numbers in this assay, from the lowest: compounds 2, 3, 4 and 1 (each within the scatter of the next).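

In this assay, the group of 11 heavy atoms on an oxygen next to a carbonyl group is rebuilt from the same atoms, joined differently, and the outcome is a 1.0-fold higher number from compound 3 to compound 4 (0.01 log units; within the scatter). The earlier compounds shown here showed only that replacing methoxy with methyl on this aromatic ring gave a 1.5-fold higher number from compound 2 to compound 3 (0.18 log units; within the scatter), so this result adds a second kind of change: rearranging the same pieces also leaves the number within the scatter, and neither step among compounds 2, 3 and 4 goes beyond it. No measurement shown here offers an explanation for this flat result.

From the compounds shown here alone, both changes at this place involve only small carbon- and oxygen-based groups on the same ring, so it remains open whether an amine, a carboxylic acid or a longer chain on this aromatic ring would move the number beyond the scatter. Compounds 2, 3 and 4 also leave open whether the same tolerance to change at this place would hold in any other assay or with a different shared core.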